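Swapping a Fluoroethyl Ether for an Oxolanyl Ether

A few compounds are considered here, and "the series" means these few. Any claim that something is new, unique, unknown or untested is made for them only; others in the source may bear on it.

Of the compounds shown here, three have been tested in a functional assay on HEK293 cells for antagonist activity at Oxytocin receptor (Homo sapiens), read by calcium flux, with a stated time of 10 min, in the presence of a further agent that is not named here; on this read-out lower numbers stand for stronger inhibition and higher numbers for weaker inhibition. Compound 1 `COCc1nnc(N2CC3CN(c4ccc(F)cc4Cl)CC32)n1-c1ccc(OC)nc1` gives 850 nM in this assay, compound 2 `COCc1nnc(C2CCN(Cc3ccc(F)cc3Cl)CC2)n1-c1ccc(OC)nc1` gives 2790 nM, and compound 3 `COc1ccc(-n2c(COCCF)nnc2N2C[C@@H]3C[C@]3(c3ccc(F)cc3Cl)C2)cn1` gives 44 nM. Compound 3 thus stands lowest of the three, with compound 1 nearest to it and compound 2 furthest from it, and both gaps lie beyond the usual scatter of this assay.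

Compound 4 `COc1ccc(-n2c(CO[C@H]3CCOC3)nnc2N2C[C@@H]3C[C@]3(c3ccc(F)cc3Cl)C2)cn1` has not yet been measured. It differs from compound 3 in one place: oxolan-3-yl in place of 2-fluoroethyl on an oxygen on a saturated carbon. The shared core and the two aromatic groups attached to it are unchanged. Among the measured compounds shown here, no pair of measured compounds differs by a comparable exchange, so there is no measured step to lean on. Compound 3 sits at 44 nM, and compound 4 is expected to remain in the same region. The expected step of a 1.5-fold higher number from compound 3 to compound 4 (0.17 log units; within the scatter) is a slight weakening, or none beyond the scatter. Compound 4 is therefore estimated at 65 nM, within a range from 20 nM to 200 nM.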

Compound 4, half-maximal inhibitory concentration: 184 nM
Estimate against measurement, compound 4: 2.8-fold (0.45 log units) below; the range from low to high includes it.
By their numbers in this assay, from the lowest: compound 3; then compound 4; then compound 1; then compound 2.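

In this assay, placing oxolan-3-yl instead of 2-fluoroethyl on this oxygen gives a 4.2-fold higher number from compound 3 to compound 4 (0.62 log units; beyond the scatter), so with the shared core and both aromatic groups unchanged, the group at this position clearly affects the read-out. The exchange alters several features at once: the entering group adds a five-membered ring, a defined stereocentre and a hydrogen-bond acceptor, while the fluorine leaves, and a single step cannot separate these features. Nothing available here explains why inhibition weakens.

The compounds shown leave open how a plain ethyl group, a 3-fluoropropyl chain or an oxetan-3-yl ring would behave on this oxygen. On these data alone, it also remains open whether oxolan-3-yl with the opposite configuration at its stereocentre would give a similar value.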